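The compounds below may be only part of what the source reports. "The series", "measured", "known", "first", "only" and "open" are said of these compounds alone.

Compound 1 `CCNc1cc(C)c2cc(NC(=O)c3ccc(Cl)c(Cl)c3)ccc2n1` gives 48600 nM in a functional assay on MCF7 cells (Homo sapiens) for antiproliferative activity, read by MTT assay, with a stated time of 72 h (a lower number here means a stronger inhibitor, a higher number a weaker inhibitor), the highest of the three numbers measured. Compound 2 `CCN1CCN(c2cc(C)c3cc(NC(=O)c4ccccc4Br)ccc3n2)CC1` gives 27500 nM in this assay, a gap from compound 1 that lies within the scatter, while compound 3 `CCN1CCN(c2cc(C)c3cc(NC(=O)c4ccc(Cl)cc4)ccc3n2)CC1` gives 1530 nM, a gap well beyond it. Among the compounds with values here, the only single-place step, an 18-fold lower number from compound 2 to compound 3 (1.25 log units; beyond the scatter), alters the ring on the carbonyl carbon, not the part of the molecule changed here. Compound 4 `Cc1cc(NCCN2CCCCC2)nc2ccc(NC(=O)c3ccc(Cl)c(Cl)c3)cc12` differs from compound 1 by piperidin-1-yl in place of hydrogen on a saturated chain carbon, two bonds along the chain from a nitrogen on an aromatic ring. Within the data shown here, no measured step bears on this change, so nothing beyond the scatter is expected in this assay. The step of a 1.6-fold lower number from compound 1 to compound 4 (0.21 log units; within the scatter) is therefore estimated to be small. Compound 4 is expected to give about 30000 nM, between 8000 nM and 100000 nM.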

Compound 4, half-maximal inhibitory concentration: 1190 nM
Compound 4: middle estimate off by 25-fold (1.40 log units), on the high side; measured number outside the range, below it.
By their numbers in this assay, from the lowest: compounds 4 and 3 (each within the scatter of the next); then compounds 2 and 1 (each within the scatter of the next).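

In this assay, the step of a 41-fold lower number from compound 1 to compound 4 (1.61 log units; beyond the scatter) shows that this position responds strongly: changing ethylamino to (2-(piperidin-1-yl)ethyl)amino, with the rest of the molecule unchanged, has a large effect on the number. Within the data shown here, the only earlier single-place step concerned the ring on the carbonyl carbon, so this is the first reading of a change at this chain. Nothing measured here accounts for the size of the step. The compounds shown leave open whether a dimethylamino group, a morpholine ring or a longer chain in place of the piperidin-1-yl group would give a similar number. They also leave open whether the step holds with another ring on the carbonyl carbon.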